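Anilide replacement series on the shared core

A few compounds are considered here, and "the series" means these few. Any claim that something is new, unique, unknown or untested is made for them only; others in the source may bear on it.

Measured so far:
compound 1 `COc1ccc(S(=O)(=O)N2CCc3cccc(NC(=O)c4cccs4)c32)cc1` — 31 nM
compound 2 `COc1ccc(S(=O)(=O)N2CCc3cccc(NS(=O)(=O)c4ccc(F)cc4)c32)cc1` — 890 nM

In a functional assay on MKN-45 cells (Homo sapiens) for cytotoxicity (on this read-out higher numbers stand for weaker inhibition and lower numbers for stronger inhibition), compound 1 gives 31 nM and compound 2 gives 890 nM. Within the data shown here, compound 2 therefore stands at the highest of the two numbers seen, and the only measured step, a 29-fold higher number from compound 1 to compound 2 (1.46 log units; beyond the scatter), is a large loss on swapping a carbonyl-linked group for a sulfonyl-linked one on the nitrogen on the aromatic ring.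

Compound 3 `COc1ccc(S(=O)(=O)N2CCc3cccc(NC(=O)N(C)c4ccccc4)c32)cc1` is not yet measured. Its change from compound 2 is methyl(phenyl)carbamoyl in place of (4-fluorophenyl)sulfonyl on a nitrogen on an aromatic ring. Among the measured compounds shown here, this step bears only on the one measured step, which ran in the opposite sense: a 29-fold higher number from compound 1 to compound 2 (1.46 log units; beyond the scatter). Compound 3 moves back from a sulfonyl to a carbonyl-bearing group, so a step toward a lower number in this assay is expected, although the entering group is not the same as that of compound 1 and the full recovery need not follow.

Compound 3 is estimated at 100 nM, within 25 nM to 400 nM, which would mean an expected step of an 8.9-fold lower number from compound 2 to compound 3 (0.95 log units; beyond the scatter).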

Compound 3, half-maximal inhibitory concentration: > 10000 nM
Compound 3: only a limit was reported (the forecaster's own chance of this, stated with the estimate: 5%); middle value at least 100-fold (2.00 log units) away from the limit.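

Compound 3 carries a limit, not a number, in this assay: the limit of > 10000 nM in this assay, at which 1 of the 3 values shown sits.

The carbonyl on the nitrogen is kept when methyl(phenyl)amino stands in place of thiophen-2-yl on a carbonyl carbon, yet the result is an at least 320-fold higher number from compound 1 to compound 3 (2.50 log units; beyond the scatter), so a carbonyl at this position does not by itself give a low number. With methyl(phenyl)carbamoyl in place of (4-fluorophenyl)sulfonyl on a nitrogen on an aromatic ring, the series shows an at least 11-fold higher number from compound 2 to compound 3 (1.05 log units; beyond the scatter), so among these three compounds the order does not follow a simple split between sulfonyl-linked and carbonyl-linked groups, and the group carried on the carbonyl carbon matters.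

The compounds shown leave open whether the methyl or the phenyl of methyl(phenyl)amino accounts for the step, and whether a phenylamino, furan-2-yl or cyclopropyl group on the carbonyl carbon would stay close to compound 1. They also leave open how a thiophen-2-ylsulfonyl group on the same nitrogen would read, which would separate the sulfonyl link from the change of ring that compound 2 carries with it.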